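This account rests on a few compounds, and the source may have more. Where it says the series, first, only, none or still open, it means among the compounds named here.

Measured so far:
compound 1 `CC1(OC(=O)N2C[C@H]3COC[C@@H](C2)[C@@H]3Oc2ncnc(Nc3ccc(C#N)cc3Cl)c2F)CC1` gives 92% in a functional assay on HEK293 cells for agonist activity at Glucose-dependent insulinotropic receptor (Homo sapiens), read by cAMP accumulation, with a stated time of 30 min; on this read-out lower numbers stand for smaller maximal responses and higher numbers for larger maximal responses;
compound 2 `CC1(OC(=O)N2C[C@H]3COC[C@@H](C2)[C@@H]3Oc2ncnc(Nc3ccccc3F)c2F)CC1` gives 78%;
compound 3 `N#Cc1ccc(Oc2ncnc(OC3C4COCC3CN(c3ncc(F)cn3)C4)c2C2CC2)c(Cl)c1` gives 56%.

Compound 2 stands second of the three numbers, below compound 1 and well above compound 3, both gaps beyond the scatter. For the measured compounds named here, the single measured step, a number 14 percentage points lower from compound 1 to compound 2 (beyond the scatter), came with 2-fluorophenyl in place of 2-chloro-4-cyanophenyl on a nitrogen on an aromatic ring.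

Compound 4 `CC1(OC(=O)N2C[C@H]3COC[C@@H](C2)[C@@H]3Oc2ncnc(Nc3c(F)cccc3F)c2F)CC1` differs from compound 2 by fluoro in place of hydrogen on an aromatic carbon. Going by the values given here, no measured step adds a fluoro to an aromatic carbon; the one step on record concerns a different exchange and bears on this change only loosely. Compound 4 is therefore expected to show a number 3 percentage points lower from compound 2 to compound 4 (within the scatter) in this assay, not beyond the scatter. Compound 4 is estimated at 75%, in a range from 55% to 95%.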

Compound 4, largest response reached (reported as percent of maximum), in percent of the reference or control that the assay uses: 78%
Compound 4: the middle estimate sits 3 percentage points below what was measured; low and high end bracket the measured number.
By their numbers in this assay, from the lowest: compound 3; then compounds 2 and 4 (each within the scatter of the next); then compound 1.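

In this assay this aromatic carbon, ortho to a large group, takes a fluoro with no change at the digits printed from compound 2 to compound 4 (within the scatter), so the second fluoro leaves the maximal response in place. The 2,6-difluorophenyl group is no closer to the 2-chloro-4-cyanophenyl group than the 2-fluorophenyl group was, with a number 14 percentage points lower from compound 1 to compound 4 (beyond the scatter). Nothing measured explains why the response holds at this position.

Open, from the compounds shown here alone, is whether methyl or methoxy on this aromatic carbon would give the same response. Also open, going by these compounds, is whether a nitrile on the 2,6-difluorophenyl group would raise it.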